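The source may hold more compounds than are shown below. What is called first, only, known or untested is meant among the compounds shown, and "the series" means these compounds.

Compound 3, `Cc1nc(S(C)(=O)=O)ccc1Oc1ncnc(OC2CCN(C(=O)c3noc(C(C)C)n3)CC2)c1F`, carries a five-membered aromatic ring on the carbonyl carbon of the shared core and, in a functional assay on isolated protein for inhibition of Glucose-dependent insulinotropic receptor (Homo sapiens), read by HTRF and cAMP accumulation (a lower number here means that less compound is needed, a higher number that more compound is needed for the effect), compound 3 gives 21.2 nM. Among the three compounds measured this stands second highest: compound 1, `Cc1nc(S(C)(=O)=O)ccc1Oc1ncnc(OC2CCN(C(=O)OC3CCC3)CC2)c1F`, gives 13.6 nM in this assay, and the difference a 1.6-fold higher number from compound 1 to compound 3 (0.19 log units; within the scatter) is within the scatter, whereas compound 2, `Cc1nc(S(C)(=O)=O)ccc1Oc1ncnc(OC2CCN(C(=O)OC(C)(C)C#N)CC2)c1F`, gives 92.9 nM, so that a 4.4-fold lower number from compound 2 to compound 3 (0.64 log units; beyond the scatter) is a modest, genuine step. Compound 4, `Cc1nc(S(C)(=O)=O)ccc1Oc1ncnc(OC2CCN(C(=O)c3nc(C(C)(C)F)no3)CC2)c1F`, differs from compound 3 only at that carbonyl carbon: a group of 9 heavy atoms (5 carbon, 2 nitrogen, 1 oxygen, 1 fluorine; one five-membered aromatic ring with 3 hetero atoms) in place of a group of 8 heavy atoms (5 carbon, 2 nitrogen, 1 oxygen; one five-membered aromatic ring with 3 hetero atoms), on a carbonyl carbon. For the measured compounds named here, no measured step reproduces this particular exchange of one five-membered aromatic ring for another that carries a fluorine; the two steps onto the same carbonyl carbon span from a gap within the scatter, a 1.6-fold higher number from compound 1 to compound 3 (0.19 log units; within the scatter), to a modest one, a 4.4-fold lower number from compound 2 to compound 3 (0.64 log units; beyond the scatter). Given that the change is small and the closest precedent, a 1.6-fold higher number from compound 1 to compound 3 (0.19 log units; within the scatter), stays within the scatter, the step of a 1.2-fold higher number from compound 3 to compound 4 (0.07 log units; within the scatter) is expected to be small and of uncertain direction. Compound 4 is therefore estimated at 25 nM in this assay, with a likely range from 10 nM to 60 nM.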

Compound 4, half-maximal effective concentration: 43.4 nM
Compound 4: the middle estimate sits 1.7-fold (0.24 log units) below what was measured; the measured number falls inside the stated range.
By their numbers in this assay, from the lowest: compounds 1 and 3 (each within the scatter of the next); then compound 4; then compound 2.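

In this assay, for the compounds shown here, this carbonyl carbon responds to an exchange of one five-membered aromatic ring with 3 hetero atoms for another, with a 2.0-fold higher number from compound 3 to compound 4 (0.31 log units; beyond the scatter), so a modest step beyond the scatter arises even between groups of the same ring type, which the earlier compounds did not show. The fluorine-bearing group also falls in the middle of the series, with a 2.1-fold lower number from compound 2 to compound 4 (0.33 log units; beyond the scatter) and a 3.2-fold higher number from compound 1 to compound 4 (0.50 log units; beyond the scatter), so it improves on 1-cyano-1-methylethoxy but does not reach cyclobutyloxy. Nothing at hand explains these steps.

The entering group differs from 5-isopropyl-1,2,4-oxadiazol-3-yl both in its fluorine and in the arrangement of its ring, and the compounds shown do not separate the two. From the compounds shown here alone, how a pyridine ring or a tert-butoxy group on this carbonyl carbon would read also remains open.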